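The source may report more compounds than this note shows. Statements on the series, on what has been measured and on what is new or still open speak of the compounds shown alone.

Compound 1, `CN1CCN(c2nc3ccccc3[nH]2)CC1`: in a functional assay on ileum for inhibition of histamine H1 receptor (Cavia porcellus) (a lower number here means a stronger inhibitor, a higher number a weaker inhibitor), compound 1 gives > 3000 nM, which is a limit of the assay.
Compound 2, `CCCn1c(N2CCN(C)CC2)nc2ccccc21`: compound 2 gives 380 nM.
Compound 3, `CCCCCCCCCCn1c(N2CCN(C)CC2)nc2ccccc21`: compound 3 gives 4200 nM.

Among the two measured numbers, compound 3 stands highest, and compound 1 gives only a limit (the limit of > 3000 nM in this assay, at which 1 of the 3 values shown sits). Compound 4, `CCSCCn1c(N2CCN(C)CC2)nc2ccccc21`, differs from compound 3 by ethylsulfanyl in place of octyl on a saturated chain carbon, two bonds along the chain from an aromatic nitrogen. Within the data shown here, two measured steps bear on this change. First, an at least 7.8-fold lower number from compound 1 to compound 2 (0.89 log units; beyond the scatter). Second, an 11-fold higher number from compound 2 to compound 3 (1.04 log units; beyond the scatter), so a long chain on the aromatic nitrogen weakened inhibition where a short one had strengthened it. The chain in compound 4 is shorter than in compound 3 and nearer in length to that of compound 2, which gives 380 nM. A clearly lower number is therefore expected for compound 4, a 6.0-fold lower number from compound 3 to compound 4 (0.78 log units; beyond the scatter). Compound 4 is estimated at 700 nM, with a likely range from 200 nM to 2500 nM.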

Compound 4, half-maximal inhibitory concentration: 19 nM
For compound 4 the middle estimate is 37-fold (1.57 log units) above the measured one; measured number below the stated range.
By their numbers in this assay, from the lowest: compound 4; then compound 2; then compound 3.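

Putting ethylsulfanyl in place of octyl gives a 220-fold lower number from compound 3 to compound 4 (2.34 log units; beyond the scatter), and measured against the short propyl chain the same position gives a 20-fold lower number from compound 2 to compound 4 (1.30 log units; beyond the scatter), so a chain carrying sulfur goes well past what the short plain chain reached. Adding the whole 2-(ethylsulfanyl)ethyl group to the free aromatic nitrogen gives an at least 150-fold lower number from compound 1 to compound 4 (2.19 log units; beyond the scatter). For compound 1 that step starts from a limit, not a number: the limit of > 3000 nM in this assay, at which 1 of the 4 values shown sits.

On these data alone, whether the sulfur itself matters, or only the chain length, stays open. A plain pentyl chain or a 2-ethoxyethyl chain in the same place would separate the two.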